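From Methylurea to Sulfamide on the Amine Nitrogen

The source may report more compounds than this note shows. Statements on the series, on what has been measured and on what is new or still open speak of the compounds shown alone.

Compound 3 `CNC(=O)NC[C@@H]1CCCc2cc(S(=O)(=O)c3cccc(F)c3)ccc21` stands second highest of the three measured compounds in an assay on isolated protein for displacement of a labelled ligand from 5-hydroxytryptamine receptor 6 (Homo sapiens); a higher number here means a weaker inhibitor, a lower number a stronger inhibitor: compound 3 gives 0.398 nM, while compound 1 `NC[C@@H]1CCCc2cc(S(=O)(=O)c3cccc(F)c3)ccc21` gives 0.0794 nM and compound 2 `O=S(=O)(O)CCCNC[C@@H]1CCCc2cc(S(=O)(=O)c3cccc(F)c3)ccc21` gives 1.26 nM. Compound 4 `NS(=O)(=O)NC[C@@H]1CCCc2cc(S(=O)(=O)c3cccc(F)c3)ccc21` differs from compound 3 by sulfamoyl in place of methylcarbamoyl on an amine nitrogen. Going by the values given here, two measured steps bear on this change at the same place. Adding methylcarbamoyl to the free amine gave a 5.0-fold higher number from compound 1 to compound 3 (0.70 log units; beyond the scatter), and exchanging 3-sulfopropyl for methylcarbamoyl gave a 3.2-fold lower number from compound 2 to compound 3 (0.50 log units; beyond the scatter), both modest. Sulfamoyl and methylcarbamoyl each carry a hydrogen-bond donor and no net charge, so the expected step is small, a 1.3-fold higher number from compound 3 to compound 4 (0.10 log units; within the scatter), with no clear direction beyond the scatter. Compound 4 is therefore estimated at 0.5 nM in this assay, within 0.15 nM to 1.6 nM.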

Compound 4, inhibition constant: 0.126 nM
Beside the measured number, compound 4's estimate is 4.0-fold (0.60 log units) above it, outside the stated range (below it).
By their numbers in this assay, from the lowest: compounds 1 and 4 (each within the scatter of the next); then compound 3; then compound 2.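

In this assay the exchange on the amine nitrogen gave a 3.2-fold lower number from compound 3 to compound 4 (0.50 log units; beyond the scatter) even though both groups carry no net charge, so methylcarbamoyl and sulfamoyl are not interchangeable here. Substitution at this nitrogen also need not raise the number: sulfamoyl in place of hydrogen gave a 1.6-fold higher number from compound 1 to compound 4 (0.20 log units; within the scatter) and in place of 3-sulfopropyl gave a 10-fold lower number from compound 2 to compound 4 (1.00 log units; beyond the scatter) while the methylcarbamoyl and 3-sulfopropyl steps from compound 1 lie beyond the scatter. Nothing measured here explains the gap between sulfamoyl and methylcarbamoyl. As far as these compounds go, whether a methanesulfonyl or acetyl group on the same nitrogen would sit nearer compound 4 or compound 3 remains open.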